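Methyl on the Ring Amide Nitrogen of Compound 1

This account rests on a few compounds, and the source may have more. Where it says the series, first, only, none or still open, it means among the compounds named here.

In an assay on cells for inhibition of Amine oxidase [flavin-containing] A (Homo sapiens), read by Amplex Red, with a stated time of 30 min (a lower number here means a stronger inhibitor, a higher number a weaker inhibitor), compound 1 `O=C1COC(c2ccc(/N=C/c3cccc(Cl)c3)cc2)=NN1` gives > 100000 nM, which is a limit of the assay rather than a number. Its neighbour compound 2 `O=C1COC(c2ccc(/N=C/c3ccc(Cl)cc3)cc2)=NN1` in this assay gives > 100000 nM, likewise a limit. Within the data shown here, the one measured step, a step that the two limits leave unreadable from compound 1 to compound 2, therefore cannot be read. Both values sit at the limit of > 100000 nM in this assay, at which 2 of the 2 values shown sit. Compound 3 `CN1N=C(c2ccc(/N=C/c3cccc(Cl)c3)cc2)OCC1=O` differs from compound 1 by methyl in place of hydrogen on an amide-type nitrogen in a ring. Among the measured compounds shown here, no measured step touches this position, and the single step that exists is unreadable, so the data give neither a direction nor a size for this change in this assay. Compound 3 is accordingly expected to sit at the limit as well, with an estimated value of 150000 nM and a range from 40000 nM to 600000 nM. The step this estimate implies, a step that the limit leaves unreadable from compound 1 to compound 3, is expected to be none beyond the scatter.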

Compound 3, half-maximal inhibitory concentration: > 100000 nM
Compound 3 was reported as a limit; the forecaster's own chance of this, stated with the estimate: 85%; the middle value lies beyond the limit too.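

In this assay compound 3 gives > 100000 nM, a limit of the assay and not a number, so the change from compound 1 to compound 3 cannot be read. The compounds shown leave open whether methyl in place of hydrogen on this ring nitrogen alters inhibition at all.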